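Swapping dihydroxyethyl for methoxyphenyl: what to expect

The compounds below may be only part of what the source reports. "The series", "measured", "known", "first", "only" and "open" are said of these compounds alone.

Of the compounds shown here, three have been measured in a functional assay (B cells) with Mus musculus as the target; a higher number here means that more compound is needed for the effect, a lower number that less compound is needed. Compound 1 `Nc1nc(O)c2c(n1)n(C1OC(CO)[C@@H](O)[C@H]1O)c(=O)n2C/C=C/c1ccccc1` gives 103 uM, compound 2 `Nc1nc(O)c2c(n1)n(C1OC(CO)[C@@H](O)[C@H]1O)c(=O)n2CC(O)CO` gives 45 uM, and compound 3 `C=CCn1c(=O)n([C@@H]2O[C@H](CO)[C@H]3OC(CCC)(CCC)O[C@H]32)c2nc(N)nc(O)c21` gives 4 uM. Among these, compound 2 holds the second highest number: its nearest neighbour is compound 1, with a higher number, and the furthest is compound 3, with a lower one.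

Compound 4 `COc1ccc(Cn2c(=O)n(C3OC(CO)[C@@H](O)[C@H]3O)c3nc(N)nc(O)c32)cc1` has not yet been measured. It differs from compound 2 in one place: 4-methoxyphenyl in place of 1,2-dihydroxyethyl on a saturated chain carbon bound to an aromatic nitrogen. Within the data shown here, only one measured step bears on this change, namely a 2.3-fold lower number from compound 1 to compound 2 (0.36 log units; beyond the scatter), where 1,2-dihydroxyethyl in place of 2-phenylethenyl on a saturated chain carbon bound to an aromatic nitrogen gave a modestly lower number. The change to compound 4 runs the other way, taking out the 1,2-dihydroxyethyl and bringing in a group with one six-membered aromatic ring of carbon only, so a modest rise of the number, of roughly that size, is expected. Among the measured compounds shown here, compound 3 differs from compound 2 in more than one place, so its value alone gives no single step to lean on.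

Compound 4 is therefore expected to give 85 uM in this assay, with a range from 30 uM to 240 uM. The expected step is a 1.9-fold higher number from compound 2 to compound 4 (0.28 log units; within the scatter).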

Compound 4, concentration for half-maximal effect: 135 uM
Compound 4: middle estimate off by 1.6-fold (0.20 log units), on the low side; the range from low to high includes it.
By their numbers in this assay, from the lowest: compound 3; then compound 2; then compounds 1 and 4 (each within the scatter of the next).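

In this assay, putting 4-methoxyphenyl in place of 1,2-dihydroxyethyl on a saturated chain carbon bound to an aromatic nitrogen gives a 3.0-fold higher number from compound 2 to compound 4 (0.48 log units; beyond the scatter), so the earlier rise seen with 2-phenylethenyl now has a second, differently built group showing the same direction. Exchanging one ring-bearing group for the other gives a 1.3-fold higher number from compound 1 to compound 4 (0.12 log units; within the scatter), so at this place 4-methoxyphenyl and 2-phenylethenyl cannot be told apart, and among the three compounds that differ here only at this group, the one without an aromatic ring has the lowest number. Nothing available explains why the number moves with this change.

As far as these compounds go, what remains open is whether the higher number follows the arrival of the aromatic ring or the loss of the hydroxyl groups, as the two go together in each step. A plain propyl group, with neither ring nor hydroxyl, or a chain ending in an amine, placed on the same core, would help to pull these two changes apart.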